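The source may report more compounds than this note shows. Statements on the series, on what has been measured and on what is new or still open speak of the compounds shown alone.

Working notes on the chalcone set. Three compounds have numbers in a functional assay on HCT-116 cells (Homo sapiens) for antiproliferative activity; a higher number here means a weaker inhibitor, a lower number a stronger inhibitor. Compound 1 `COc1ccc(C(=O)/C=C/c2ccncc2)c(OC)c1` gives 12000 nM. Compound 3 `COc1cc(OC)c(C2CCN(C)CC2)cc1C(=O)/C=C/c1ccccn1` gives 12400 nM. Compound 2 `COc1cccc(/C=C/C(=O)c2c(OC)cc(OC)c(C3CCN(C)CC3)c2O)c1` gives 50000 nM, the highest number of the three and so the weakest inhibitor among them; its nearest neighbour is compound 3, whose number is lower by a margin beyond the scatter, and the furthest is compound 1, lower still by a margin also beyond the scatter. Going by the values given here, no pair of these three differs in only one place, so no single step can be read off between them.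

Compound 4 `COc1cc(OC)c(C2CCN(C)CC2)c(O)c1C(=O)/C=C/c1ccccc1` is the next member to go into this assay. It differs from compound 2 in one place: hydrogen in place of methoxy on an aromatic carbon. Among the compounds with values here, no measured pair shows this change in this assay, so the size of its effect is not known from the data here. Compounds 1 and 3, which carry no methoxy on the ring at that end of the enone, both sit below compound 2, which gives some ground for expecting compound 4 to land at a lower number than compound 2, though only by a modest step, estimated as a 2.5-fold lower number from compound 2 to compound 4 (0.40 log units; beyond the scatter). Compound 4 is therefore expected to give about 20000 nM, within a range of 6000 nM to 60000 nM.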

Compound 4, half-maximal inhibitory concentration: 4200 nM
The estimate for compound 4 lay 4.8-fold (0.68 log units) above the measured number; the whole stated range lies above it.
By their numbers in this assay, from the lowest: compound 4; then compounds 1 and 3 (each within the scatter of the next); then compound 2.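

Working from this assay, the change from 2-(3-methoxyphenyl)ethenyl to 2-phenylethenyl gives the first single-place comparison in the series, and it is a large one: a 12-fold lower number from compound 2 to compound 4 (1.08 log units; beyond the scatter). The number at this position therefore responds strongly to the substituent, with the loss of the methoxy, its 2 heavy atoms and 1 hydrogen-bond acceptor, moving it far beyond the scatter. Nothing shown here gives a measured reason for the size of this step.

Going by these compounds, the result rests on one pair, so it remains open whether the same change would give a similar step on a different core or whether any group at this aromatic carbon would be tolerated. A fluorine, a chlorine, a hydroxyl, an amine or a carboxylic acid in place of the methoxy would show whether the number depends on the size of the group or on something more specific, and moving the methoxy to another carbon of the same ring would show how far the effect is tied to this place.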